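Chloro Position Shift Carried Onto a Second Core

The source may hold more compounds than are shown below. What is called first, only, known or untested is meant among the compounds shown, and "the series" means these compounds.

Compound 1 `O=C(Cn1nc(-c2ccccc2)c2ccccc2c1=O)Nc1cccc(Cl)c1` bears a 3-chlorophenyl group on the amide-type nitrogen. In a functional assay on HepG2 cells (Homo sapiens) for antiproliferative activity, read by sulforhodamine B assay, with a stated time of 72 h (a higher number here means a weaker inhibitor, a lower number a stronger inhibitor), compound 1 gives 3290 nM. Compound 2 `O=C(Cn1nc(-c2ccccc2)c2ccccc2c1=O)Nc1ccc(Cl)cc1` differs from it by 4-chlorophenyl in place of 3-chlorophenyl on an amide-type nitrogen, and in this assay compound 2 gives 10300 nM; that change made a 3.1-fold higher number from compound 1 to compound 2 (0.50 log units; beyond the scatter). Compound 3 `O=C(Cn1nc(Cc2ccccc2)c2ccccc2c1=O)Nc1cccc(Cl)c1` keeps the 3-chlorophenyl group but has a different core, the difference being (benzyl in place of phenyl on an aromatic carbon). In this assay compound 3 gives 14300 nM, a step of a 4.3-fold higher number from compound 1 to compound 3 (0.64 log units; beyond the scatter).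

Compound 4 `O=C(Cn1nc(Cc2ccccc2)c2ccccc2c1=O)Nc1ccc(Cl)cc1` has not yet been measured. It differs from compound 3 by 4-chlorophenyl in place of 3-chlorophenyl on an amide-type nitrogen, which is the same change as that made from compound 1 to compound 2; the surroundings of the place are described in the same words in both cases. The change has been seen only once, so its size on the second core is uncertain. Compound 4 is expected to show a step of a 2.9-fold higher number from compound 3 to compound 4 (0.47 log units; beyond the scatter), resting on compound 1 to compound 2 having given a 3.1-fold higher number from compound 1 to compound 2 (0.50 log units; beyond the scatter). Compound 4 is therefore estimated at 42000 nM in this assay, between 14000 nM and 130000 nM.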

Compound 4, half-maximal inhibitory concentration: > 100000000 nM
Compound 4: a limit, no number; the forecaster's own chance of this, stated with the estimate: 25%; middle value at least 2300-fold (3.37 log units) away from the limit.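

Compound 4 gives > 100000000 nM in this assay, which is a limit of the assay and not a number. On the core of compound 3, 4-chlorophenyl in place of 3-chlorophenyl gives an at least 6900-fold higher number from compound 3 to compound 4 (3.84 log units; beyond the scatter), so the direction seen on the core of compound 1 carries over but the size of the step does not: the same change on two cores in this assay, a 3.1-fold higher number (0.50 log units; beyond the scatter) from compound 1 to compound 2 and an at least 6900-fold higher number (3.84 log units; beyond the scatter) from compound 3 to compound 4, at least 2200-fold (3.34 log units) apart, beyond the scatter of two such steps

Benzyl in place of phenyl, with 4-chlorophenyl on the amide-type nitrogen, gives an at least 9700-fold higher number from compound 2 to compound 4 (3.98 log units; beyond the scatter), so this change does not keep its size between the two settings either, although a limit fixes no true size for either step and two pairs give no rule for further cores: the same change on two cores in this assay, a 4.3-fold higher number (0.64 log units; beyond the scatter) from compound 1 to compound 3 and an at least 9700-fold higher number (3.98 log units; beyond the scatter) from compound 2 to compound 4, at least 2200-fold (3.34 log units) apart, beyond the scatter of two such steps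

Open, from the compounds shown here alone, is whether the sharp loss belongs only to benzyl combined with 4-chlorophenyl. An unsubstituted phenyl on the amide-type nitrogen, or a longer chain such as phenylethyl in place of benzyl, would show whether the steps stay modest or again become large.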